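The compounds below may be only part of what the source reports. "The series", "measured", "known", "first", "only" and "open" are said of these compounds alone.

Compound 1, `CCN(C(=O)OC)c1c(N)nc(-c2nn(Cc3ccccc3F)c3ncccc23)nc1N`: 0.2 uM
Compound 2, `Nc1nc(-c2nn(Cc3ccccc3F)c3ncccc23)nc(N)c1NC(=O)OCC(F)(F)F`: 0.2 uM
Compound 3, `Nc1nc(-c2nn(Cc3ccccc3F)c3ncccc23)nc(N)c1N1CCOC1=O`: 0.3 uM

All three share one core and differ only in the group carried on one aromatic carbon. In an assay on cells for activation of Guanylate cyclase soluble subunit alpha-1 (Rattus norvegicus), read by cGMP accumulation and immunoassay, with a stated time of 10 min (a higher number here means that more compound is needed for the effect, a lower number that less compound is needed), compound 1 gives 0.2 uM, compound 2 gives 0.2 uM and compound 3 gives 0.3 uM. Compound 3 has the highest number of the three, but its gaps to the others are small: a 1.5-fold higher number from compound 1 to compound 3 (0.18 log units; within the scatter) and a 1.5-fold higher number from compound 2 to compound 3 (0.18 log units; within the scatter), while no change at the digits printed from compound 1 to compound 2 (within the scatter). None of these steps reaches beyond the scatter, so the three compounds behave alike in this assay.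

Compound 4, `Nc1nc(-c2nn(Cc3ccccc3F)c3ncccc23)nc(N)c1N1C[C@H](C(F)(F)F)OC1=O`, keeps the oxazolidinone of compound 3 and adds one group to it: trifluoromethyl in place of hydrogen on a saturated ring carbon. Among the compounds with values here, the closest precedent is the step from compound 1 to compound 2, where a trifluoromethyl-bearing chain entered the side group without a change beyond the scatter, and the exchange of whole side groups across compounds 1, 2 and 3 also left the numbers essentially unchanged. A small change within the scatter is therefore expected for compound 4 in this assay, giving no change at the digits printed from compound 3 to compound 4 (within the scatter). Compound 4 is estimated at 0.3 uM, with a likely range from 0.1 uM to 0.9 uM.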

Compound 4, minimum effective concentration: 0.2 uM
Compound 4: the middle estimate sits 1.5-fold (0.18 log units) above what was measured; the measured number falls inside the stated range.
By their numbers in this assay, from the lowest: compounds 1, 2, 4 and 3 (each within the scatter of the next).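

The earlier compounds shown here exchanged whole side groups, whereas here a single hydrogen on the ring of compound 3 gives way to trifluoromethyl on the saturated ring carbon next to the ring oxygen, and in this assay this addition leaves the reading within the scatter (a 1.5-fold lower number from compound 3 to compound 4 (0.18 log units; within the scatter)). Set against the two open-chain side groups, the substituted ring also stays level (no change at the digits printed from compound 2 to compound 4 (within the scatter); no change at the digits printed from compound 1 to compound 4 (within the scatter)), so among these four compounds neither closing the side group into a ring nor adding trifluoromethyl to that ring moves the number beyond the scatter. Nothing available here accounts for this flat result.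

From the compounds shown here alone, whether a methyl group, a hydroxyl group or an amine on this same ring carbon would read alike remains open, as does what a carboxylic acid or a longer chain would do there. The compounds shown also carry trifluoromethyl in only one spatial arrangement at that carbon, so the mirror-image arrangement remains an open question too.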